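One Ring Swap on Two Related Cores

The source may report more compounds than this note shows. Statements on the series, on what has been measured and on what is new or still open speak of the compounds shown alone.

Compound 1 `Oc1ccc(O)c(-c2cc(-c3ccc(Cl)cc3)nn2-c2ccccc2)c1` was tested in a functional assay on cells (Cancer cell lines, Homo sapiens) for cytotoxicity, read by sulforhodamine B assay, with a stated time of 48 h (on this read-out higher numbers stand for weaker inhibition of growth and lower numbers for stronger inhibition of growth), and gave 14600 nM. Compound 3 `O=C1C=CC(=O)C(c2cc(-c3ccc(Cl)cc3)nn2-c2ccccc2)=C1`, which differs from it in one place, gave 36500 nM in this assay. The change behind this pair is a group of 8 heavy atoms (6 carbon, 2 oxygen; one six-membered non-aromatic ring of carbon only) in place of a group of 8 heavy atoms (6 carbon, 2 oxygen; one six-membered aromatic ring of carbon only), on an aromatic carbon, and it produced a 2.5-fold higher number from compound 1 to compound 3 (0.40 log units; beyond the scatter).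

Compound 2 `CC(=O)NS(=O)(=O)c1ccc(-n2nc(-c3ccccc3)cc2-c2cc(O)ccc2O)cc1` stands on a different core; how its core differs from that of compound 1 is not broken down here. In this assay, among the compounds with values here, compound 2 gives 100000 nM, the highest of the three numbers so far.

Compound 4 `CC(=O)NS(=O)(=O)c1ccc(-n2nc(-c3ccccc3)cc2C2=CC(=O)C=CC2=O)cc1` has not yet been measured in this assay. It arises from compound 2 by a group of 8 heavy atoms (6 carbon, 2 oxygen; one six-membered non-aromatic ring of carbon only) in place of a group of 8 heavy atoms (6 carbon, 2 oxygen; one six-membered aromatic ring of carbon only), on an aromatic carbon. Within the data shown here, this is the same kind of change as the one from compound 1 to compound 3, though the surroundings differ: in compound 1 the group sits next to the ring atom that bears a phenyl group and two ring bonds from the ring atom that bears a 4-chlorophenyl group, whereas in compound 2 it sits next to the ring atom that bears a large group and two ring bonds from the ring atom that bears a phenyl group.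

Because of a 2.5-fold higher number from compound 1 to compound 3 (0.40 log units; beyond the scatter), the step from compound 2 to compound 4 is expected to be a 1.8-fold higher number from compound 2 to compound 4 (0.26 log units; within the scatter). Compound 4 is therefore estimated at 180000 nM in this assay, most likely between 70000 nM and 450000 nM.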

Compound 4, concentration for 50% growth inhibition: 100000 nM
Compound 4: middle estimate off by 1.8-fold (0.26 log units), on the high side, and the stated range covers the measured number.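

In this assay, replacing the 2,5-dihydroxyphenyl group with the non-aromatic ring on the second core gave no change at the digits printed from compound 2 to compound 4 (within the scatter). Set beside the same change on the first core, this step cannot be told apart from the earlier one: the same change on two cores in this assay, a 2.5-fold higher number (0.40 log units; beyond the scatter) from compound 1 to compound 3 and no change at the digits printed (within the scatter) from compound 2 to compound 4, 2.5-fold (0.40 log units) apart, within the scatter of two such steps. Within the data shown here, the two cores therefore give no sign that the change behaves differently from one to the other, but with a single pair on each core this does not show that the step has one fixed size, nor does it explain why only the step on the first core lies beyond the scatter.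

The compounds shown leave open whether the change would read the same on a core that pairs the 4-chlorophenyl group of compound 1 with the large group of compound 2, which would help separate the contributions of these two parts. They also leave open how it would behave with an amine or a carboxylic acid in place of that large group.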